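Trimming an Aminophenyl Group Down to Methyl

A few compounds are considered here, and "the series" means these few. Any claim that something is new, unique, unknown or untested is made for them only; others in the source may bear on it.

In a functional assay on HCT-116 cells (Homo sapiens) for cytotoxicity, read by MTT assay, with a stated time of 72 h (on this read-out higher numbers stand for weaker inhibition and lower numbers for stronger inhibition), compound 2 `Nc1ccc(Nc2c(C(=O)NCc3ccc(F)cc3)nc(Br)c3cccnc23)cc1` gives 7000 nM, the lowest of the two plain numbers available. Compound 3 `N[C@H]1CC[C@H](Nc2c(C(=O)NCc3ccc(F)cc3)nc(N3CCCCC3)c3cccnc23)CC1` gives 8500 nM in this assay, a value within the usual scatter of that of compound 2, so the two cannot be ordered. Compound 1 `CC(C)(C)OC(=O)N1CCN(c2c(C(=O)NCc3ccc(F)cc3)nc(Br)c3cccnc23)CC1` gives > 10000 nM in this assay, which is a limit rather than a number: the limit of > 10000 nM in this assay, at which 1 of the 3 values shown sits. Compound 4 `CNc1c(C(=O)NCc2ccc(F)cc2)nc(Br)c2cccnc12` has not yet been measured; it differs from compound 2 by methyl in place of 4-aminophenyl on a nitrogen on an aromatic ring. Among the compounds with values here, no measured pair shows what such a change does. With nothing to go by, the step from compound 2 to compound 4 is expected to be modest and toward weaker inhibition, a 2.1-fold higher number from compound 2 to compound 4 (0.33 log units; beyond the scatter). The value expected for compound 4 is 15000 nM, between 5000 nM and 50000 nM.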

Compound 4, half-maximal inhibitory concentration: > 20000 nM
Compound 4 gave a limit, no number (the forecaster's own chance of this, stated with the estimate: 60%); middle value at least 1.3-fold (0.12 log units) away from the limit.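

In this assay, methyl in place of 4-aminophenyl on a nitrogen on an aromatic ring gives an at least 2.8-fold higher number from compound 2 to compound 4 (0.45 log units; beyond the scatter). This first one-place comparison shows that, at this position, the change from (4-aminophenyl)amino to methylamino weakens inhibition rather than leaving it unchanged. The result for compound 4 is a limit of the assay and not a number: the limit of > 20000 nM in this assay, at which 1 of the 4 values shown sits.

As far as these compounds go, the full size of the step therefore stays open. Also open, from the compounds shown here alone, is whether the ring or the amine on it matters here; a plain phenyl group on the same nitrogen would tell these apart.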